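This account rests on a few compounds, and the source may have more. Where it says the series, first, only, none or still open, it means among the compounds named here.

Measured in a functional assay on the whole organism (strain Wistar albino) for inhibition, with Rattus norvegicus as the target, read by paw edema, with a stated time of 4 h, at a dose of 70 mg/kg by the oral route; a higher number here means more inhibition at the dose given (going by the name of the read-out), a lower number less inhibition:

compound 1 `CC(C)Cc1ccc(C(C)c2nnc3sc(-c4ccc(Cl)cc4Cl)nn23)cc1`: 80.3%
compound 2 `CC(C)Cc1ccc(C(C)c2nnc3sc(COc4ccc(Cl)cc4Cl)nn23)cc1`: 38.6%
compound 3 `CCCCNc1nn2c(C(C)c3ccc(CC(C)C)cc3)nnc2s1`: 80.3%

Compound 3 stands level with compound 1 at the digits printed, the two together the highest of the three numbers in this assay. The step of no change at the digits printed from compound 1 to compound 3 (within the scatter) lies within the scatter, while the step of a number 41.7 percentage points higher from compound 2 to compound 3 (beyond the scatter) is large and beyond it, so compound 2 sits well apart from the other two.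

Compound 4 `CC(C)Cc1ccc(C(C)c2nnc3sc(Nc4ccccc4)nn23)cc1` differs from compound 3 by phenyl in place of butyl on a nitrogen on an aromatic ring.

Within the data shown here, two measured steps bear on this change. The step of no change at the digits printed from compound 1 to compound 3 (within the scatter) shows that 2,4-dichlorophenyl and butylamino on the same aromatic carbon give a level reading, so with a six-membered aromatic ring of carbon only at that end of the core the number is level with that seen with the butyl chain. The step of a number 41.7 percentage points lower from compound 1 to compound 2 (beyond the scatter) shows that a large drop appears only when (2,4-dichlorophenoxy)methyl is put there. Anilino in place of butylamino keeps the nitrogen on the aromatic ring, and the expectation is therefore no step beyond the scatter, a number 2.3 percentage points lower from compound 3 to compound 4 (within the scatter).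

Compound 4 is expected to give 78% in this assay, within a range from 60% to 90%.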

Compound 4, a percentage reported as inhibition, in the whole organism at one dose (the size of the read-out at that dose, not a potency): 68.2%
Beside the measured number, compound 4's estimate is 9.8 percentage points above it; low and high end bracket the measured number.
By their numbers in this assay, from the lowest: compound 2; then compound 4; then compounds 1 and 3 (each within the scatter of the next).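

The nitrogen on an aromatic ring is not indifferent to its substituent in this assay: phenyl in place of butyl gives a number 12.1 percentage points lower from compound 3 to compound 4 (beyond the scatter) and so is a real, modest change. The level reading of 2,4-dichlorophenyl and butylamino on the aromatic carbon therefore does not extend to anilino, as a number 12.1 percentage points lower from compound 1 to compound 4 (beyond the scatter) also shows. Anilino still keeps clear of the low reading of (2,4-dichlorophenoxy)methyl, with a number 29.6 percentage points higher from compound 2 to compound 4 (beyond the scatter) on that carbon, so it takes an intermediate place among these groups.

From the compounds shown here alone, whether cyclohexyl or benzyl on that nitrogen would stay level with butyl or fall towards phenyl remains open. Nothing available here accounts for the drop from butyl to phenyl.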